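Notes on compound 4 against compounds 1 to 3

This account rests on a few compounds, and the source may have more. Where it says the series, first, only, none or still open, it means among the compounds named here.

Compound 3 `COc1cc[nH]c1/C=C1\C(=O)Nc2ccc([N+](=O)[O-])c(N[C@H]3CC[C@H](N)C3)c21` stands at a limit in a functional assay on RKO cells (Homo sapiens) for antiproliferative activity, read by MTT assay, with a stated time of 5 days; on this read-out lower numbers stand for stronger inhibition and higher numbers for weaker inhibition: compound 3 gives < 15 nM, which is a limit of the assay and not a number. Compound 1 `COc1cc[nH]c1/C=C1\C(=O)Nc2ccc([N+](=O)[O-])c(N3CC[C@@H](N)C3)c21` likewise reaches only a limit, giving < 10 nM in this assay. Among the measured compounds shown here, compound 2 `COc1cc[nH]c1/C=C1\C(=O)Nc2ccc([N+](=O)[O-])c(-n3ccnc3)c21` is the one compound with a full number, giving 3920 nM. The two limits the limit of < 10 nM in this assay, at which 1 of the 3 values shown sits, and the limit of < 15 nM in this assay, at which 1 of the 3 values shown sits, cap the top of the series, so the step that the two limits leave unreadable from compound 1 to compound 3 cannot be read. The readable steps are an at least 390-fold higher number from compound 1 to compound 2 (2.59 log units; beyond the scatter) and an at least 260-fold lower number from compound 2 to compound 3 (2.41 log units; beyond the scatter), both large: the two amine-bearing substituents sit at a limit, the 1H-imidazol-1-yl compound sits far higher.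

Compound 4 `COc1cc[nH]c1/C=C1\C(=O)Nc2ccc([N+](=O)[O-])c(N3CCCC(O)C3)c21` differs from compound 3 by 3-hydroxypiperidin-1-yl in place of (3-aminocyclopentyl)amino on an aromatic carbon. A saturated ring is kept on the aromatic carbon, but the entering group carries a hydroxyl instead of an amine and has one hydrogen-bond donor in place of two. For the measured compounds named here, the steps of an at least 390-fold higher number from compound 1 to compound 2 (2.59 log units; beyond the scatter) and an at least 260-fold lower number from compound 2 to compound 3 (2.41 log units; beyond the scatter) bear on it only indirectly, showing the gap between amine-bearing and non-amine substituents; no measured pair tests a hydroxyl in that place. A loss against compound 3 in this assay is therefore expected, beyond the scatter yet smaller than the gap to compound 2. Compound 4 is estimated at 300 nM, expected between 60 nM and 1500 nM, which means an expected step of an at least 20-fold higher number from compound 3 to compound 4 (1.30 log units; beyond the scatter).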

Compound 4, half-maximal inhibitory concentration: 105 nM
Compound 4: middle estimate off by 2.9-fold (0.46 log units), on the high side; low and high end bracket the measured number.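

In this assay, the step of a 37-fold lower number from compound 2 to compound 4 (1.57 log units; beyond the scatter) shows that a large part of the gap seen with the 1H-imidazol-1-yl group closes on this aromatic carbon, ortho to a nitro group, with a 3-hydroxypiperidin-1-yl group that carries a hydroxyl and no primary amino group. The amine-bearing substituents still stay ahead of it beyond the scatter, with an at least 7.0-fold higher number from compound 3 to compound 4 (0.84 log units; beyond the scatter) and an at least 10-fold higher number from compound 1 to compound 4 (1.02 log units; beyond the scatter), and neither of the two goes against this within the four compounds. Compound 3 stands at a limit of the assay, so the step that starts from it gives only a minimum: the limit of < 15 nM in this assay, at which 1 of the 4 values shown sits.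

The step between compound 1 and compound 3 cannot be read, and compound 1 also stands at a limit, so the full size of the lead held by the amine-bearing substituents remains open: the limit of < 10 nM in this assay, at which 1 of the 4 values shown sits. The compounds shown also do not separate the exchange of amine for hydroxyl from the change to a six-membered ring, a question that a 3-aminopiperidin-1-yl group on the same carbon of the shared core would address.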